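The source may hold more compounds than are shown below. What is called first, only, known or untested is meant among the compounds shown, and "the series" means these compounds.

Compound 1 `CCn1c(CNc2ccccc2)nnc1SCc1nc2cc(C(=O)C(C)C)ccc2o1` is measured in an assay on isolated protein for inhibition of long-chain fatty acid transport protein 1 (Homo sapiens) (a higher number here means a weaker inhibitor, a lower number a stronger inhibitor), where compound 1 gives 600 nM. Compound 2 `CCn1c(CNc2ccccc2)nnc1SCc1nc2cc(F)ccc2o1` carries fluoro in place of the isopropylcarbonyl, and in this assay compound 2 gives only a limit, > 1000 nM. Compound 3 `CC/C(=N/OC)c1ccc2oc(CSc3nnc(CNc4ccccc4)n3CC)nc2c1` in this assay likewise gives only a limit, > 1000 nM. Two of the three values sit at the limit of > 1000 nM in this assay, at which 2 of the 3 values shown sit, so compound 3 stands at the weak end of what is shown, without a number of its own. The step of an at least 1.6-fold higher number from compound 1 to compound 3 (0.22 log units; that floor lies within the scatter) is thus only a floor, and the step that the two limits leave unreadable from compound 2 to compound 3 cannot be read at all. Compound 4 `CCC(O)c1ccc2oc(CSc3nnc(CNc4ccccc4)n3CC)nc2c1` differs from compound 3 by a group of 4 heavy atoms (3 carbon, 1 oxygen; no ring) in place of a group of 6 heavy atoms (4 carbon, 1 nitrogen, 1 oxygen; no ring), on an aromatic carbon. Among the measured compounds shown here, no measured step involves a 1-hydroxypropyl group; the only step with a numbered start on that aromatic carbon, an at least 1.6-fold higher number from compound 1 to compound 3 (0.22 log units; that floor lies within the scatter), shows that leaving the isopropylcarbonyl weakened inhibition by at least the floor. Compound 4 is therefore expected to stay near the limit, with a step that the limit leaves unreadable from compound 3 to compound 4 measured against a limit. The estimate for compound 4 is 1500 nM, between 500 nM and 5000 nM.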

Compound 4, half-maximal inhibitory concentration: > 1000 nM
Compound 4: only a limit was reported (the forecaster's own chance of this, stated with the estimate: 60%); the middle value lies beyond the limit too.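

With the 1-hydroxypropyl group, which carries one hydrogen-bond donor where the group in compound 3 has none, this aromatic carbon still gives no numbered value, and a third compound now stands at the same limit: the limit of > 1000 nM in this assay, at which 3 of the 4 values shown sit. Compared with the isopropylcarbonyl group of compound 1, the change gives an at least 1.6-fold higher number from compound 1 to compound 4 (0.22 log units; that floor lies within the scatter), so only a floor is known, and it cannot separate compound 4 from compound 1 beyond the usual scatter. The steps from compound 2 and compound 3 to compound 4 cannot be read, since both ends are limits.

Going by these compounds, how far compounds 2, 3 and 4 lie beyond that limit stays open. So does whether another carbonyl group on this aromatic carbon, such as acetyl or cyclopropylcarbonyl, or a carboxylic acid, would give a numbered value.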